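The source may hold more compounds than are shown below. What is called first, only, known or untested is meant among the compounds shown, and "the series" means these compounds.

Compound 1, `O=c1[nH]nc2n(c1=O)CCN2c1ccccc1`: 0%
Compound 2, `Cc1ccc(N2CCn3c2n[nH]c(=O)c3=O)cc1`: 20%
Compound 3, `N=c1c(=O)[nH]nc2n1CCN2c1cccc(Cl)c1`: 36%

In a functional assay on A549 cells (Homo sapiens) for antiproliferative activity, with a stated time of 72 h, tested at 10 ug/mL (a lower number here means a weaker effect, a higher number a stronger effect of the compound at the concentration tested), compound 1 gives 0%, the lowest of the three numbers; compound 2 stands closest, and compound 3 furthest, with its value of 36% well beyond the scatter above compound 1. Compound 4, `Cc1ccccc1N1CCn2c1n[nH]c(=O)c2=O`, differs from compound 1 in one place: methyl in place of hydrogen on an aromatic carbon. Within the data shown here, the one measured step that bears on this is the addition of a methyl group in a different position on the same ring, a number 20 percentage points higher from compound 1 to compound 2 (beyond the scatter). A methyl group entering at the position ortho to a large group may not behave the same way, so the expectation is a modest rise, a number 14 percentage points higher from compound 1 to compound 4 (beyond the scatter), with wide uncertainty. Compound 4 is therefore estimated at 14%, between 0% and 32%.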

Compound 4, a percentage reported as inhibition, at one concentration (the size of the read-out at that concentration, not a potency): 24%
The estimate for compound 4 lay 10 percentage points below the measured number, and the stated range covers the measured number.
By their numbers in this assay, from the lowest: compound 1; then compounds 2 and 4 (each within the scatter of the next); then compound 3.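

In this assay a methyl ortho to a large group also raises the number, a number 24 percentage points higher from compound 1 to compound 4 (beyond the scatter), so the gain seen with compound 2 is not confined to one place on the aromatic ring. Compound 2 gives 20% and compound 4 gives 24%, values within the scatter of each other, so these two methyl placements cannot be told apart here. No evidence at hand explains the rise. Going by these compounds, whether a methoxy group or an amine at this same place would raise the number as well remains open.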